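A few compounds are considered here, and "the series" means these few. Any claim that something is new, unique, unknown or untested is made for them only; others in the source may bear on it.

Measured in an ADME assay on a cell-free system (plasma, Rattus norvegicus) for protein binding:
- Compound 1 `Cc1ccc(-c2cc(C(=O)N[C@H](C)c3ccc(C(F)(F)F)[n+]([O-])c3)cc(C(C)(C)O)c2)nc1` gives 62.4%
- Compound 2 `C[C@@H](NC(=O)c1cc(-c2ccc(F)cn2)cc(C(C)(C)O)c1)c1ccc(C(F)(F)F)[n+]([O-])c1` gives 55.3%

For the measured compounds named here, compound 2 stands within the scatter of the only other measured compound, with a 1.2-fold higher unbound fraction from compound 1 to compound 2 (0.08 log units; within the scatter). That step, fluoro in place of methyl on an aromatic carbon, is the only measured one bearing on compound 3 `C[C@@H](NC(=O)c1cc(-c2ccc(Cl)cn2)cc(C(C)(C)O)c1)c1ccc(C(F)(F)F)[n+]([O-])c1`. Its change is chloro in place of fluoro on an aromatic carbon, chloro in place of fluoro, para to a large group. With so small a precedent, no step beyond the scatter is expected in this assay. The estimate means a 1.2-fold lower unbound fraction from compound 2 to compound 3 (0.07 log units; within the scatter), an expected step of modest size. For compound 3 the expected value is 62%, with an estimated range of 48% to 75%.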

Compound 3, plasma protein binding: 76.2%
For compound 3 the middle estimate is 1.6-fold (0.20 log units) (unbound fraction) above the measured one; the whole stated range lies below it.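

In this assay, 5-fluoropyridin-2-yl to 5-chloropyridin-2-yl gives a 1.9-fold lower unbound fraction from compound 2 to compound 3 (0.27 log units; within the scatter) and chloro in place of methyl at the same place gives a 1.6-fold lower unbound fraction from compound 1 to compound 3 (0.20 log units; within the scatter) on the shared core. For the compounds shown here, with methyl, fluoro and chloro now compared on this aromatic carbon, no printed step among them lies beyond the scatter. Nothing available here accounts for the size of these steps. Going by these compounds, a methoxy group, a nitrile or an amine at this place remains open. So does whether chloro for fluoro would give a similar step on another core.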